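The source may report more compounds than this note shows. Statements on the series, on what has been measured and on what is new or still open speak of the compounds shown alone.

Measured in a functional assay (aorta) with Rattus norvegicus as the target; a lower number here means that less compound is needed, a higher number that more compound is needed for the effect:
- compound 1 `CN(C)/C(=N\C#N)C1=CC(C)(C)Oc2ccc(C(F)(F)F)cc21`: 12600 nM
- compound 2 `CN(C)/C(=N\C#N)C1=CC(C)(C)Oc2ccccc21`: > 31600 nM (a limit of the assay, not a number)
- compound 3 `CNC(=O)C1=CC(C)(C)Oc2ccc([N+](=O)[O-])cc21`: 10.7 nM

Compound 3, at 10.7 nM, has the lower of the two actual numbers, and compound 1 stands far higher at 12600 nM. The two also differ in more than one place, so this gap cannot be assigned to a single change.

The next compound is compound 4 `CN(C)C(=S)C1=CC(C)(C)Oc2ccc([N+](=O)[O-])cc21`, which differs from compound 3 on a double-bonded ring carbon: a group of 5 heavy atoms (3 carbon, 1 nitrogen, 1 sulfur; no ring) in place of a group of 4 heavy atoms (2 carbon, 1 nitrogen, 1 oxygen; no ring), on a double-bonded ring carbon. The aromatic part stays the same.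

Among the measured compounds shown here, the only measured step is an at least 2.5-fold higher number from compound 1 to compound 2 (0.39 log units; beyond the scatter). It concerns hydrogen in place of trifluoromethyl on an aromatic carbon, not the place changed here, so it gives no direct size for this change. For the measured compounds named here, it shows only that a single change can move beyond the scatter in this assay.

Going by the values given here, with no measured step at this place, the estimate is broad. Compound 3 already has the lowest number at 10.7 nM, so a higher number, beyond the scatter, is the more likely outcome. The expected shift is a 14-fold higher number from compound 3 to compound 4 (1.15 log units; beyond the scatter). Compound 4 is expected at 150 nM, with an estimated range of 15 nM to 2500 nM.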

Compound 4, half-maximal effective concentration: 955 nM
For compound 4 the middle estimate is 6.4-fold (0.80 log units) below the measured one; the measured number falls inside the stated range.
By their numbers in this assay, from the lowest: compound 3; then compound 4; then compound 1. At a limit, above all of these: compound 2.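

In this assay, among the compounds shown here, the first measured step at the double-bonded ring carbon is large: an 89-fold higher number from compound 3 to compound 4 (1.95 log units; beyond the scatter). With the aromatic part unchanged, this shows that the group on this carbon alone can move the number well beyond the scatter, and that the methylcarbamoyl of compound 3 gives the lower number of this pair. The swap is compound, however, replacing the oxygen with sulfur, adding one heavy atom and going from 1 hydrogen-bond donor to 0 hydrogen-bond donors, and nothing measured here bears on why the number rises.

The compounds shown leave open which part of the swap carries the step, since a dimethylcarbamoyl group, with the carbonyl kept and two methyl groups on the nitrogen, and a methylthiocarbamoyl group, with sulfur and one methyl group on the nitrogen, are not among them. Also open, as far as these compounds go, is how far this place tolerates other groups, such as an unsubstituted carbamoyl group, a carboxylic acid or an amide with a longer chain on the nitrogen.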